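A few compounds are considered here, and "the series" means these few. Any claim that something is new, unique, unknown or untested is made for them only; others in the source may bear on it.

Measured compounds:
- compound 1, `O=C(/C(=C/C1CCCCC1)CCl)c1ccccc1`, 30000 nM
- compound 2, `CC(=O)OC/C(=C\C1CCCCC1)C(=O)c1ccccc1`, 21000 nM
- compound 3, `CCC(/C=C(\COC(C)=O)C(=O)c1ccccc1)CC`, 50000 nM

In a functional assay on HeLa cells (Homo sapiens) for inhibition, read by sulforhodamine B assay, with a stated time of 48 h (a higher number here means a weaker inhibitor of growth, a lower number a stronger inhibitor of growth), compound 3 carries the highest number of the three. Among the compounds with values here, its gap to compound 1 is within the scatter; only the step of a 2.4-fold higher number from compound 2 to compound 3 (0.38 log units; beyond the scatter) reaches beyond it. The other measured step, a 1.4-fold lower number from compound 1 to compound 2 (0.15 log units; within the scatter), stays within the scatter and concerns a different part of the structure.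

Compound 4, `CC(=O)OC/C(=C\c1ccc(Cl)cc1)C(=O)c1ccccc1`, is the next compound in the series. Its change from compound 3 is 4-chlorophenyl in place of pentan-3-yl on a double-bonded chain carbon bound to a double-bonded chain carbon. Within the data shown here, the only measured step that touches this place is a 2.4-fold higher number from compound 2 to compound 3 (0.38 log units; beyond the scatter), where a ring left and a branched chain entered and the number rose. Here a ring enters again at the same place, so the expectation is a step back in the other direction, of about the same modest size, rather than nothing. Compound 4 is therefore expected to give 18000 nM in this assay, with a range from 6000 nM to 50000 nM. The expected step from compound 3 is a 2.8-fold lower number from compound 3 to compound 4 (0.44 log units; beyond the scatter).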

Compound 4, concentration for 50% growth inhibition: 3200 nM
Estimate against measurement, compound 4: 5.6-fold (0.75 log units) above, outside the stated range (below it).
By their numbers in this assay, from the lowest: compound 4; then compounds 2, 1 and 3 (each within the scatter of the next, the first and the last beyond it).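

At the double-bonded chain carbon bound to a double-bonded chain carbon, this assay responds far more strongly to 4-chlorophenyl than the earlier exchange of two saturated groups suggested (a 2.4-fold higher number from compound 2 to compound 3 (0.38 log units; beyond the scatter)): the new steps are large against pentan-3-yl (a 16-fold lower number from compound 3 to compound 4 (1.19 log units; beyond the scatter)) and modest against cyclohexyl (a 6.6-fold lower number from compound 2 to compound 4 (0.82 log units; beyond the scatter)). A ring as such does not account for the full change, since the step from cyclohexyl to 4-chlorophenyl also replaces one ring with another and still lies beyond the scatter. No measurement given here explains the size of these steps.

Still open, on these data alone, is how much of the change belongs to the aromatic ring and how much to its chlorine; a plain phenyl or a 4-methoxyphenyl at this place would separate the two. Also open, as far as these compounds go, is whether chloro in place of acetoxy stays within the scatter with 4-chlorophenyl, as it does with cyclohexyl (a 1.4-fold lower number from compound 1 to compound 2 (0.15 log units; within the scatter)).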